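The source may report more compounds than this note shows. Statements on the series, on what has been measured and on what is new or still open speak of the compounds shown alone.

Measured compounds:
- compound 1 `CCCCc1cnc(C(CC)Cc2ccc(-c3ccccc3C(=O)O)cc2)[nH]1`: 2720 nM
- compound 2 `N#Cc1ccccc1Cc1cnc(CCc2ccc(-c3ccccc3C(=O)O)cc2)[nH]1`: 5480 nM
- compound 3 `CCCCc1cnc(/C=C/c2ccc(-c3ccccc3C(=O)O)cc2)[nH]1`: 4380 nM

All three share a biphenyl carboxylic acid joined through a two-carbon spacer to an imidazole core, and differ in the group on the imidazole and in the spacer. In an in vitro functional assay on cells for agonist activity at Bombesin receptor subtype-3 (Homo sapiens), read by luminescence and calcium flux (on this read-out lower numbers stand for an effect already at smaller amounts and higher numbers for an effect only at larger amounts of compound), compound 2 gives 5480 nM, the highest of the three numbers. The gap to compound 3 is small, and even the gap to compound 1 stays within the usual scatter, so none of the three can be set apart from the others on these data.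

Compound 4 `O=C(O)c1ccccc1-c1ccc(CCc2ncc(Cc3ccccc3)[nH]2)cc1` is the next analogue of compound 2. The change is hydrogen in place of cyano on an aromatic carbon; what remains is a plain benzyl group on the imidazole in place of the 2-cyanobenzyl. Going by the values given here, no measured pair in this set isolates this kind of change, so there is nothing to lean on for its size.

The working expectation for compound 4 in this assay is therefore a step of about a 1.1-fold higher number from compound 2 to compound 4 (0.04 log units; within the scatter), small and undirected, essentially within the scatter. Compound 4 is expected at 6000 nM, with a range of 2000 nM to 18000 nM.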

Compound 4, half-maximal effective concentration: 205 nM
Estimate against measurement, compound 4: 29-fold (1.47 log units) above, outside the stated range (below it).
By their numbers in this assay, from the lowest: compound 4; then compounds 1, 3 and 2 (each within the scatter of the next).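

In this assay, going by these compounds alone, the loss of the nitrile from the 2-cyanobenzyl group, leaving plain benzyl, gives a 27-fold lower number from compound 2 to compound 4 (1.43 log units; beyond the scatter), the only step so far and one well beyond the scatter. Compounds 1, 2 and 3 could not be told apart from one another, so they gave no sign of how much this aromatic carbon, ortho to a large group, matters; the pair of compound 2 and compound 4 now marks it as a place where a single substituent counts heavily, with hydrogen there and cyano not tolerated to the same degree. No measurement at hand accounts for the size of this step.

The compounds shown leave open whether any group on this carbon carries the same penalty or whether it is specific to the nitrile, which a fluorine, a methyl or a methoxy group at the same place would settle. Also open, on these data alone, is whether the benzyl group brings a similar gain on the branched and the alkene spacers of compound 1 and compound 3, which carry a butyl chain instead.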